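This account rests on a few compounds, and the source may have more. Where it says the series, first, only, none or still open, it means among the compounds named here.

Of the compounds shown here, three built on one shared core have been measured in a functional assay on isolated protein for inhibition of Glucose-dependent insulinotropic receptor (Rattus norvegicus), read by HTRF and cAMP accumulation; a higher number here means that more compound is needed for the effect, a lower number that less compound is needed. Compound 1 `Cc1nc(S(C)(=O)=O)ccc1Oc1ncnc(OC2CCN(C(=O)OC(C)(C)C(F)(F)F)CC2)c1F` gives 47.2 nM, compound 2 `Cc1nc(S(C)(=O)=O)ccc1Oc1ncnc(OC2CCN(C(=O)OC(C)(C)CF)CC2)c1F` gives 138 nM, and compound 3 `Cc1nc(S(C)(=O)=O)ccc1Oc1ncnc(OC2CCN(C(=O)OC3COC3)CC2)c1F` gives 2500 nM, the highest of the three; the steps of a 53-fold higher number from compound 1 to compound 3 (1.72 log units; beyond the scatter) and an 18-fold higher number from compound 2 to compound 3 (1.26 log units; beyond the scatter) are both large, whereas a 2.9-fold higher number from compound 1 to compound 2 (0.47 log units; beyond the scatter) is modest. Compound 4 `Cc1nc(S(C)(=O)=O)ccc1Oc1ncnc(OC2CCN(C(=O)OC3(C(F)(F)F)COC3)CC2)c1F` differs from compound 3 by trifluoromethyl in place of hydrogen on a saturated ring carbon. The two large steps show how much the oxetan-3-yl group costs relative to the fluorinated branched groups, while the modest step shows that the count of fluorines in such a group matters less; a trifluoromethyl on the oxetane ring is therefore expected to win back part of that loss, a decrease in this assay of a 10-fold lower number from compound 3 to compound 4 (1.00 log units; beyond the scatter). Compound 4 is thus estimated at 250 nM, within a range of 60 nM to 1000 nM.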

Compound 4, half-maximal effective concentration: 342 nM
Compound 4: middle estimate off by 1.4-fold (0.14 log units), on the low side; measured number inside the range.
By their numbers in this assay, from the lowest: compound 1; then compound 2; then compound 4; then compound 3.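

Adding trifluoromethyl to the saturated ring carbon of the oxetane recovers much of the loss seen with the plain oxetan-3-yl group in this assay (a 7.3-fold lower number from compound 3 to compound 4 (0.86 log units; beyond the scatter)). The 3-(trifluoromethyl)oxetan-3-yl group still falls short of both branched chain groups, though only modestly (a 2.5-fold higher number from compound 2 to compound 4 (0.39 log units; beyond the scatter); a 7.2-fold higher number from compound 1 to compound 4 (0.86 log units; beyond the scatter)). No evidence is available to explain these differences.

From the compounds shown here alone, it remains open whether a methyl or a nitrile on the same ring carbon would recover as much as trifluoromethyl does.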